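A few compounds are considered here, and "the series" means these few. Any claim that something is new, unique, unknown or untested is made for them only; others in the source may bear on it.

Working notes on the series.

Compound 1 `Cc1ccc(/C=N/NC(=O)COc2cccc3ccccc23)cc1` is the starting point here. In an ADME assay on HEL cells (Homo sapiens) for cytotoxicity (a higher number here means that more compound is tolerated, a lower number that less compound is tolerated), compound 1 gives 20 ug/mL. The nearest companion is compound 2 `C/C(=N\NC(=O)COc1cccc2ccccc12)c1ccc(O)cc1`, which in this assay gives 20 ug/mL, so the two stand level at the digits shown and together hold the lowest of the three numbers. Compound 3 `C/C(=N\NC(=O)COc1cccc2ccccc12)c1ccc([N+](=O)[O-])cc1` gives 100 ug/mL in this assay; this is the furthest of the measured values from compound 1. Within the data shown here, the one step recorded is a 5.0-fold higher number from compound 2 to compound 3 (0.70 log units; beyond the scatter).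

The change now followed is 2-phenylethenyl in place of 4-methylphenyl on a carbon with a double bond to nitrogen, giving compound 4 `O=C(COc1cccc2ccccc12)N/N=C/C=C/c1ccccc1`. The shared core is kept and only the group attached to that carbon is exchanged. Among the measured compounds shown here, none of the measured steps touches this position, and the one recorded step concerns a different substituent, so it offers no direct guide. With nothing in the data pointing either way, the expected step in this assay is none beyond the scatter, that is no change at the digits printed from compound 1 to compound 4 (within the scatter). For compound 4 the estimate in this assay is 20 ug/mL, with a range from 10 ug/mL to 50 ug/mL.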

Compound 4, minimum cytotoxic concentration: 100 ug/mL
Compound 4: middle estimate off by 5.0-fold (0.70 log units), on the low side; the measured number lies above the stated range.
By their numbers in this assay, from the lowest: compounds 1 and 2 (each within the scatter of the next); then compounds 3 and 4 (each within the scatter of the next).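

In this assay the exchange of 4-methylphenyl for 2-phenylethenyl on a carbon with a double bond to nitrogen gives a 5.0-fold higher number from compound 1 to compound 4 (0.70 log units; beyond the scatter) and so shows that this position, untouched by the earlier step, responds to a change of group. The two groups share one six-membered aromatic ring of carbon only, 0 hydrogen-bond donors, 0 hydrogen-bond acceptors and no net charge, while the entering group adds a double bond outside aromatic rings. No measurement at hand accounts for the step.

Open, from the compounds shown here alone, is whether the step follows that double bond, which a 2-phenylethyl group on the same carbon would test, or the departure of 4-methylphenyl itself. Also open, going by these compounds, is how an amine or a carboxylic acid at this carbon would read in this assay against the two groups seen so far.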